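A few compounds are considered here, and "the series" means these few. Any claim that something is new, unique, unknown or untested is made for them only; others in the source may bear on it.

Measured so far:
compound 1, `N#Cc1c(N2CCC(c3ccccc3)CC2)ccn(CC2CCC2)c1=O`, 269%
compound 2, `N#Cc1c(N2CCC(c3ccccc3F)CC2)ccn(CC2CC2)c1=O`, 282%

Two compounds of the series have been run in a functional assay on CHO cells for positive allosteric modulation of metabotropic glutamate receptor 2 (Homo sapiens), with a stated time of 30 min; a lower number here means a smaller maximal response, a higher number a larger maximal response. Compound 1 gives 269%. Compound 2 gives 282%, the highest of the two numbers; compound 1 lies lower, and the gap to it is beyond the usual scatter. Within the data shown here, with only two compounds measured, no step between them is tabulated, and the two differ in more than one place, so what the pair shows is limited to the two values themselves.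

The next compound is compound 3, `COc1ccc(C2CCN(c3ccn(CC4CC4)c(=O)c3C#N)CC2)cc1`, not yet measured in this assay. Against compound 2 the change is 4-methoxyphenyl in place of 2-fluorophenyl on a saturated ring carbon. Nothing measured in the series bears on this exchange, so the direction of the step is open. The expectation is a modest step, a number 22 percentage points lower from compound 2 to compound 3 (beyond the scatter), plausibly within or only slightly beyond the scatter. For compound 3 the estimated maximal response in this assay is 260%, with the range 205% to 320%.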

Compound 3, largest response reached (Emax), in percent of the reference or control that the assay uses: 257%
Compound 3: the middle estimate sits 3 percentage points above what was measured; low and high end bracket the measured number.
By their numbers in this assay, from the lowest: compound 3; then compound 1; then compound 2.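

In this assay, among these compounds, this is the first exchange that can be read in one place: on the saturated ring carbon, 4-methoxyphenyl in place of 2-fluorophenyl gives a number 25 percentage points lower from compound 2 to compound 3 (beyond the scatter) and is a modest step. The maximal response therefore depends on the substituted phenyl at this position, although compound 3 still reaches 257% with a hydrogen-bond acceptor counted in the entering group and none in the leaving one. Nothing on hand explains the step.

The exchange alters both the substituent and its place on the phenyl ring, so this single step cannot separate fluoro from methoxy or the 2-position from the 4-position, and the matching 4-fluorophenyl and 2-methoxyphenyl groups would be needed to divide the two changes. Also open, going by these compounds, is how far the position extends beyond substituted phenyl groups, for example to a pyridyl ring or a phenyl ring carrying an aminomethyl group or a carboxylic acid, and whether the step holds with cyclobutylmethyl in place of cyclopropylmethyl on the core.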